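Para-methoxy on the phenyl of compound 3: expectation for compound 4

The source may hold more compounds than are shown below. What is called first, only, known or untested is meant among the compounds shown, and "the series" means these compounds.

Measured so far in an assay on isolated protein for inhibition of ribosomal protein S6 kinase alpha-5 (Homo sapiens), read by mobility shift assay, tested at 30 uM; on this read-out higher numbers stand for more inhibition at the one concentration tested (going by the name of the read-out) and lower numbers for less inhibition:
compound 1 `Nc1n[nH]c2cc(-c3ccccn3)[nH]c(=O)c12`: 35%
compound 2 `COCCNc1nc(C)cc2nn(-c3ccccc3)c(N)c12`: 3%
compound 3 `Nc1c2c(=O)[nH]c(-c3ccccc3)cc2nn1-c1ccccc1`: 13%

Compound 3 stands second highest of the three numbers in this assay. Its nearest neighbour is compound 2, whose number in this assay lies within the scatter of that of compound 3, so no order between compound 3 and compound 2 can be read from these data. The furthest is compound 1, whose number in this assay is higher and beyond the scatter. Within the data shown here, no pair of measured compounds differs in a single place, so no measured single step is available to lean on.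

Compound 4 `COc1ccc(-c2cc3nn(-c4ccccc4)c(N)c3c(=O)[nH]2)cc1` is the next compound in the series. It differs from compound 3 by methoxy in place of hydrogen on an aromatic carbon.

Among the measured compounds shown here, with no comparable measured step, the expectation rests on compound 3 alone. The step of a number 2 percentage points higher from compound 3 to compound 4 (within the scatter) is expected to be small, in no particular direction, and not beyond the scatter. Compound 4 is therefore estimated to give 15% in this assay, with a range from 2% to 35%.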

Compound 4, a percentage reported as inhibition, at one concentration (the size of the read-out at that concentration, not a potency): 6%
Beside the measured number, compound 4's estimate is 9 percentage points above it; the range from low to high includes it.
By their numbers in this assay, from the lowest: compounds 2, 4 and 3 (each within the scatter of the next); then compound 1.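

Methoxy in place of hydrogen gives the series its first single-place comparison in this assay, and the step reads a number 7 percentage points lower from compound 3 to compound 4 (within the scatter). The difference from phenyl to 4-methoxyphenyl, on an aromatic carbon para to a large group, therefore cannot be told from the usual scatter, and the two numbers allow no order between compound 3 and compound 4. There is no measured evidence that bears on this result.

As far as these compounds go, whether a different group on this same carbon, such as an amine, a carboxylic acid or a longer chain like butoxy, would give a step beyond the scatter remains open. Also open, from the compounds shown here alone, is whether methoxy would read the same at another carbon of this ring or on the core of compound 1, since a single step at one concentration says nothing about either.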